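The source may hold more compounds than are shown below. What is called first, only, known or untested is meant among the compounds shown, and "the series" means these compounds.

Measured compounds:
compound 1 `O=C(/C=N/Nc1ccc([N+](=O)[O-])cc1[N+](=O)[O-])NCCCCCCCNc1ccnc2cc(Cl)ccc12` – 11100 nM
compound 2 `O=C(/C=N/NCc1ccccc1)NCCCCCCCNc1ccnc2cc(Cl)ccc12` – 14600 nM
compound 3 `O=C(/C=N/Nc1c(Cl)cc(C(F)(F)F)cc1Cl)NCCCCCCCNc1ccnc2cc(Cl)ccc12` – 9200 nM

In a functional assay on MRC5 cells (Homo sapiens) for cytotoxicity, read by colorimetric assay and MTT assay (a higher number here means that more compound is tolerated, a lower number that less compound is tolerated), compound 3 gives 9200 nM. Its standing against the other two is told by the steps of a 1.2-fold lower number from compound 1 to compound 3 (0.08 log units; within the scatter) and a 1.6-fold lower number from compound 2 to compound 3 (0.20 log units; within the scatter), so the three compounds cannot be told apart on these numbers; the remaining step, a 1.3-fold higher number from compound 1 to compound 2 (0.12 log units; within the scatter), is of the same kind. All three differ only in the group carried on the amine nitrogen that sits next to the double-bonded nitrogen, and none of those exchanges moved the readout beyond the scatter.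

Compound 4 `Cc1cc(N/N=C/C(=O)NCCCCCCCNc2ccnc3cc(Cl)ccc23)nc2c1c(C)nn2C` is not yet measured. The change from compound 3 is a group of 12 heavy atoms (9 carbon, 3 nitrogen; one five-membered aromatic ring with 2 hetero atoms, one six-membered aromatic ring with 1 hetero atom) in place of a group of 12 heavy atoms (7 carbon, 3 fluorine, 2 chlorine; one six-membered aromatic ring of carbon only), on an amine nitrogen. Going by the values given here, every step so far that exchanged the group at this place stayed within the scatter, so in this assay no step beyond the scatter is expected for compound 4, in either direction. Compound 4 is therefore estimated at 10500 nM, with a range from 4500 nM to 24000 nM, which is expected to mean a step of a 1.1-fold higher number from compound 3 to compound 4 (0.06 log units; within the scatter).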

Compound 4, half-maximal cytotoxic concentration: 1800 nM
Estimate against measurement, compound 4: 5.8-fold (0.77 log units) above, outside the stated range (below it).
By their numbers in this assay, from the lowest: compound 4; then compounds 3, 1 and 2 (each within the scatter of the next).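

At the amine nitrogen whose other neighbour is the double-bonded nitrogen, exchanging the group can move the number in this assay beyond the scatter, which the earlier exchanges did not do: the new group gives a 5.1-fold lower number from compound 3 to compound 4 (0.71 log units; beyond the scatter) and an 8.1-fold lower number from compound 2 to compound 4 (0.91 log units; beyond the scatter) and also a 6.2-fold lower number from compound 1 to compound 4 (0.79 log units; beyond the scatter) in the same direction. The step from compound 3 comes with no change in the heavy-atom count of the group, and the entering group is the only one of the four with hetero atoms in its rings. No evidence is available on what lies behind this drop.

The compounds shown leave open whether the five-membered or the six-membered ring of the entering group carries the step. They also leave open how a single ring with a hetero atom, or the same group bearing an amine or a carboxylic acid, would stand.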